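A few compounds are considered here, and "the series" means these few. Any claim that something is new, unique, unknown or untested is made for them only; others in the source may bear on it.

Within the data shown here, compound 2 `C1=C(c2cncc(Oc3ccccc3)c2)CC2CNCC1C2` gives 0.7 nM in an in vitro assay on SH-EP1 cells for displacement of a labelled ligand from Neuronal acetylcholine receptor; alpha4/beta2 (Homo sapiens) (a lower number here means a stronger inhibitor, a higher number a weaker inhibitor), the lowest of the two numbers known; compound 1 `Clc1ccc(Oc2cncc(C3=CC4CNCC(C3)C4)c2)cc1` gives 1.9 nM in this assay, and the change a 2.7-fold lower number from compound 1 to compound 2 (0.43 log units; beyond the scatter) marks that gap. Compound 3 `FC(F)(F)c1cncc(C2=CC3CNCC(C2)C3)c1` differs from compound 2 by trifluoromethyl in place of phenoxy on an aromatic carbon. Among the measured compounds shown here, no measured step bears on this change: the single known step, from compound 1 to compound 2, alters only a substituent on the phenoxy ring, which now leaves altogether, so it offers little guidance. The step is expected to be a 5.7-fold higher number from compound 2 to compound 3 (0.76 log units; beyond the scatter), toward a weaker inhibitor. Compound 3 is thus expected to give 4 nM in this assay, within 0.8 nM to 25 nM.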

Compound 3, inhibition constant: 0.7 nM
Estimate against measurement, compound 3: 5.7-fold (0.76 log units) above, and the stated range ends above it.
By their numbers in this assay, from the lowest: compounds 2 and 3 (each within the scatter of the next); then compound 1.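

Trifluoromethyl in place of phenoxy gives no change at the digits printed from compound 2 to compound 3 (within the scatter) in this assay. Compounds 1 and 2 differed only by a substituent on the phenoxy ring, whereas compound 3 shows that, on this aromatic carbon two atoms from the ring nitrogen, the low number does not depend on keeping that ring or the oxygen. No available data explain why the two groups match here.

From the compounds shown here alone, it remains open whether the number would hold with only hydrogen at this position, or with an amine or a carboxylic acid there.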